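From aryl swaps to a 2-methoxyphenyl guess

This account rests on a few compounds, and the source may have more. Where it says the series, first, only, none or still open, it means among the compounds named here.

- Compound 1 `CCC1=C(O)c2c(oc(-c3ccc(C(C)C)cc3)cc2=O)C(CC)(CC)C1=O` gives 1.08 uM
- Compound 2 `CCOc1ccc(-c2cc(=O)c3c(o2)C(CC)(CC)C(=O)C(CC)=C3O)cc1` gives 7.54 uM
- Compound 3 `CCC1=C(O)c2c(oc(-c3cccc(F)c3)cc2=O)C(CC)(CC)C1=O` gives 3.09 uM

All three values come from a functional assay on KBVIN cells (Homo sapiens) for antiproliferative activity, read by sulforhodamine B assay, with a stated time of 3 days; a higher number here means that more compound is needed for the effect, a lower number that less compound is needed. In this small set, compound 3 at 3.09 uM holds the middle place. It lies clearly on the lower side of compound 2, as a 2.4-fold lower number from compound 2 to compound 3 (0.39 log units; beyond the scatter) shows, and clearly on the higher side of compound 1, as a 2.9-fold higher number from compound 1 to compound 3 (0.46 log units; beyond the scatter) shows.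

Compound 4 `CCC1=C(O)c2c(oc(-c3ccccc3OC)cc2=O)C(CC)(CC)C1=O` keeps the shared core and changes only the aryl group, with 2-methoxyphenyl in place of 3-fluorophenyl on an aromatic carbon next to the ring oxygen: 2-methoxyphenyl in place of 3-fluorophenyl on an aromatic carbon.

Among the compounds with values here, no measured compound carries this exact group, so the evidence is indirect. The nearest guide is compound 2, whose 4-ethoxyphenyl also has an oxygen-linked chain, and the swap to compound 3 gave a 2.4-fold lower number from compound 2 to compound 3 (0.39 log units; beyond the scatter). The other aryl swaps, a 7.0-fold higher number from compound 1 to compound 2 (0.84 log units; beyond the scatter) and a 2.9-fold higher number from compound 1 to compound 3 (0.46 log units; beyond the scatter), were also modest. A modest change is therefore expected here, leaning towards a higher number in this assay and perhaps staying within the scatter. The expected step is a 1.5-fold higher number from compound 3 to compound 4 (0.16 log units; within the scatter). For compound 4 the estimated value is 4.5 uM, with an expected range from 1.5 uM to 12 uM.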

Compound 4, concentration for half-maximal effect: 3.26 uM
Compound 4: the middle estimate sits 1.4-fold (0.14 log units) above what was measured; the range from low to high includes it.
By their numbers in this assay, from the lowest: compound 1; then compounds 3 and 4 (each within the scatter of the next); then compound 2.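

Putting 2-methoxyphenyl in place of 3-fluorophenyl on this aromatic carbon next to the ring oxygen gives a 1.1-fold higher number from compound 3 to compound 4 (0.02 log units; within the scatter) with no separation between the two aryl groups, even though they carry different substituents at different places on the phenyl ring. The two other steps put the new group in the same middle stretch of the set (a 2.3-fold lower number from compound 2 to compound 4 (0.36 log units; beyond the scatter); a 3.0-fold higher number from compound 1 to compound 4 (0.48 log units; beyond the scatter)), so having an oxygen-linked group on the phenyl ring does not by itself bring the high number of the 4-ethoxyphenyl group, and the 4-isopropylphenyl group of compound 1 keeps the lowest number. Nothing measured here explains why these aryl groups match or differ.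

Each aryl group shown differs from the others in both its substituent and where that substituent sits, so the contribution of each of these two features remains unresolved. On these data alone, it is also open whether this aromatic carbon would accept a phenyl ring carrying an amine or a carboxylic acid, or a longer chain than the isopropyl of compound 1, and whether any of these would give a lower number.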